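Halogen swap on the chalcone aryl ring: dichloro to difluoro

The compounds below may be only part of what the source reports. "The series", "measured", "known", "first", "only" and "open" are said of these compounds alone.

Measured so far:
- compound 1 `COc1cc(-c2cc(/C=C/C(=O)c3ccc(N)cc3)[nH]n2)cc(OC)c1OC`: -93%
- compound 2 `COc1cc(-c2cc(/C=C/C(=O)c3ccc(Cl)c(Cl)c3)[nH]n2)cc(OC)c1OC`: 18%
- compound 3 `COc1ccc(-c2cc(/C=C/C(=O)c3cc(OC)c(OC)c(OC)c3)[nH]n2)cc1OC`: -93%

In a functional assay on UO-31 cells (Homo sapiens) for cytotoxicity, read by sulforhodamine B assay, with a stated time of 48 h, tested at 100 uM (on this read-out lower numbers stand for a stronger effect and higher numbers for a weaker effect at the one concentration tested), compound 2 stands highest of the three numbers; both compound 1 and compound 3 sit far lower, each beyond the scatter. For the measured compounds named here, the only step in the set with one change is a number 111 percentage points higher from compound 1 to compound 2 (beyond the scatter), which swaps the whole aryl group on the carbonyl carbon and is large.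

Compound 4 `COc1cc(-c2cc(/C=C/C(=O)c3ccc(F)c(F)c3)[nH]n2)cc(OC)c1OC` is not yet measured. Its change from compound 2 is 3,4-difluorophenyl in place of 3,4-dichlorophenyl on a carbonyl carbon. Going by the values given here, no measured step exchanges one halogen for another, so the size of this step has no direct guide; the one known step concerns a different group and only shows that the aryl group on the carbonyl carbon can move the number a long way. With the same substitution pattern kept, the expected step of a number 23 percentage points lower from compound 2 to compound 4 (beyond the scatter) is small or within the scatter, with a wide range allowed. For compound 4 the expected value in this assay is -5%, estimated between -70% and 40%.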

Compound 4, a percentage reported as activity, at one concentration (the size of the read-out at that concentration, not a potency): -16%
Beside the measured number, compound 4's estimate is 11 percentage points above it, within the range that was stated.
By their numbers in this assay, from the lowest: compounds 1 and 3 (each within the scatter of the next); then compound 4; then compound 2.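

In this assay the exchange of halogen alone, with the substitution pattern kept, gives a number 34 percentage points lower from compound 2 to compound 4 (beyond the scatter) and so shows that the identity of the halogen on the aryl group at the carbonyl carbon matters at this position. The 3,4-dihalophenyl pattern therefore does not fix the number by itself. Set against the 4-aminophenyl group, the 3,4-difluorophenyl group gives a number 77 percentage points higher from compound 1 to compound 4 (beyond the scatter). This leaves compound 4 between compound 1 and compound 2, so this position shows a graded range rather than two separate levels. No measurement bears on the reason for either step.

As far as these compounds go, whether the number keeps moving along the halogens, as with a 3,4-dibromophenyl group, remains open. From the compounds shown here alone, it is also open how a monochlorophenyl group or a carboxylic acid on this aryl ring would compare.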